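This account rests on a few compounds, and the source may have more. Where it says the series, first, only, none or still open, it means among the compounds named here.

Compound 1 `C#CCn1nnc2c(C(N)=O)ncn2c1=O` gives 35600 nM in a functional assay on SNB-19 cells (Homo sapiens) for inhibition, read by MTT assay, with a stated time of 7 days; on this read-out lower numbers stand for stronger inhibition of growth and higher numbers for weaker inhibition of growth. Compound 2 `NC(=O)c1ncn2c(=O)n(Cc3ccccc3)nnc12` reaches only a limit, > 50000 nM, in this assay. The change between them is phenyl in place of ethynyl on a saturated chain carbon bound to an aromatic nitrogen; it makes an at least 1.4-fold higher number from compound 1 to compound 2 (0.14 log units; that floor lies within the scatter), a floor set by the limit of > 50000 nM in this assay, at which 1 of the 3 values shown sits. Compound 3 `C#CC/N=N/Nc1[nH]cnc1C(N)=O` gives 39100 nM in this assay, and its number and that of compound 1 sit within the scatter of each other. The difference between the two cores is not broken down here. Compound 4 `NC(=O)c1nc[nH]c1N/N=N/Cc1ccccc1` carries the same kind of change that leads to compound 2: phenyl in place of ethynyl on a saturated chain carbon bound to a double-bonded nitrogen, the place differing in that the saturated chain carbon is bound to a double-bonded nitrogen rather than to an aromatic nitrogen. Compound 4 is expected to show a 1.5-fold higher number from compound 3 to compound 4 (0.19 log units; within the scatter). That expectation rests on an at least 1.4-fold higher number from compound 1 to compound 2 (0.14 log units; that floor lies within the scatter), whose size is only a floor set by the limit of > 50000 nM in this assay, at which 1 of the 3 values shown sits. Compound 4 is estimated at 60000 nM, between 30000 nM and 120000 nM, and may well come back as a limit.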

Compound 4, concentration for 50% growth inhibition: > 50000 nM
Compound 4: a limit, no number; the forecaster's own chance of this, stated with the estimate: 60%; the middle value does not contradict the limit.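

On the second core, phenyl in place of ethynyl gives an at least 1.2-fold higher number from compound 3 to compound 4 (0.10 log units; that floor lies within the scatter) in this assay. Compound 4 gives > 50000 nM, which is a limit and not a number. Set side by side, the two cores show no sign that the change behaves differently, yet neither step has a full size, so carrying it over is neither confirmed nor ruled out: the same change on two cores in this assay, an at least 1.4-fold higher number (0.14 log units; that floor lies within the scatter) from compound 1 to compound 2 and an at least 1.2-fold higher number (0.10 log units; that floor lies within the scatter) from compound 3 to compound 4; the limit leaves it open whether they differ

Going by these compounds, how far the phenyl compounds, compound 2 and compound 4, lie past that limit stays open: the limit of > 50000 nM in this assay, at which 2 of the 4 values shown sit. Also open is whether an amine, a carboxylic acid or a longer chain in place of ethynyl would give a readable number on either core.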